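The compounds below may be only part of what the source reports. "The series", "measured", "known", "first", "only" and "open" are said of these compounds alone.

Compound 3 `CCC(=O)Nc1cccc(Oc2nc(Nc3ccc(N4CCC(C)CC4)cc3)ncc2Cl)c1` stands lowest of the three compounds measured in an assay on isolated protein for inhibition of NUAK family SNF1-like kinase 2 (Homo sapiens), read by ADP-Glo, with a stated time of 60 min, tested at 10 uM, in the presence of a further agent that is not named here (on this read-out higher numbers stand for more inhibition at the one concentration tested (going by the name of the read-out) and lower numbers for less inhibition), where compound 3 gives 24.8%. Compound 1 `CCC(=O)Nc1cccc(Oc2nc(Nc3ccc(N4CCN(C)CC4)cc3)ncc2Cl)c1` gives 82.6% and compound 2 `CCC(=O)Nc1cccc(Oc2nc(Nc3ccc(N4CCC(OC)CC4)cc3)ncc2Cl)c1` gives 53.4%, so the step of a number 57.8 percentage points lower from compound 1 to compound 3 (beyond the scatter) was large and the step of a number 28.6 percentage points lower from compound 2 to compound 3 (beyond the scatter) modest. Compound 4 `CCC(=O)Nc1cccc(Oc2nc(Nc3ccc(N(C)C)cc3)ncc2Cl)c1` differs from compound 3 by dimethylamino in place of 4-methylpiperidin-1-yl on an aromatic carbon. Among the measured compounds shown here, no measured step exchanges the ring for an open-chain group, so the bearing steps are indirect: a number 57.8 percentage points lower from compound 1 to compound 3 (beyond the scatter) and a number 29.2 percentage points lower from compound 1 to compound 2 (beyond the scatter) show that what sits on this aromatic carbon moves the read-out considerably. Compound 4 is therefore expected to differ from compound 3 by a number 15.2 percentage points higher from compound 3 to compound 4 (beyond the scatter), with an estimated value of 40%, between 15% and 70%.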

Compound 4, a percentage reported as inhibition, at one concentration (the size of the read-out at that concentration, not a potency): 31.7%
For compound 4 the middle estimate is 8.3 percentage points above the measured one, within the range that was stated.
By their numbers in this assay, from the lowest: compounds 3 and 4 (each within the scatter of the next); then compound 2; then compound 1.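

In this assay, dimethylamino and 4-methylpiperidin-1-yl on this aromatic carbon lie within the scatter of each other, with a number 6.9 percentage points higher from compound 3 to compound 4 (within the scatter). The ring of compound 3 therefore carries no measurable gain over the open dimethylamino group, whereas a number 21.7 percentage points lower from compound 2 to compound 4 (beyond the scatter) and a number 50.9 percentage points lower from compound 1 to compound 4 (beyond the scatter) show that the 4-methoxy and 4-methylpiperazine rings do, so a ring alone does not account for the higher numbers. No evidence here gives a reason for this. Still open, as far as these compounds go, is whether morpholin-4-yl or unsubstituted piperazin-1-yl on this carbon would match compound 1 or compound 2.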